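The source may hold more compounds than are shown below. What is called first, only, known or untested is meant among the compounds shown, and "the series" means these compounds.

Of the compounds shown here, three sharing one core have been tested in a functional assay on KYSE-410 cells (Homo sapiens) for antiproliferative activity, read by MTT assay, with a stated time of 72 h; a higher number here means a weaker inhibitor, a lower number a stronger inhibitor. Compound 1 `CC(=O)c1ccc(-c2ccc3c(C(=O)Nc4cccc(F)c4)cc(=O)[nH]c3c2)cc1`, bearing a 4-acetylphenyl group, reads > 20000 nM, which is a limit and not a number. Compound 2 `O=C(Nc1cccc(F)c1)c1cc(=O)[nH]c2cc(-c3cccc(F)c3)ccc12`, bearing a 3-fluorophenyl group, gives 10900 nM. Compound 3 `O=C(Nc1cccc(F)c1)c1cc(=O)[nH]c2cc(-c3ccccc3F)ccc12`, bearing a 2-fluorophenyl group, reads > 20000 nM, again only a limit. Compound 3 therefore shares (the limit of > 20000 nM in this assay, at which 2 of the 3 values shown sit), and no number fixes its place.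

Compound 4 `Cc1cc(-c2ccc3c(C(=O)Nc4cccc(F)c4)cc(=O)[nH]c3c2)c(C)cc1F` exchanges that 2-fluorophenyl for 4-fluoro-2,5-dimethylphenyl on the same aromatic carbon of the core: 4-fluoro-2,5-dimethylphenyl in place of 2-fluorophenyl on an aromatic carbon. Within the data shown here, two measured steps bear on this change, since both exchange one substituted phenyl group for another at that carbon. They are an at least 1.8-fold higher number from compound 2 to compound 3 (0.26 log units; that floor lies within the scatter) and an at least 1.8-fold lower number from compound 1 to compound 2 (0.26 log units; that floor lies within the scatter), and each is a floor that lies within the scatter. Neither step adds methyl groups, so the size of that addition remains unmeasured. In this assay, no step beyond the scatter is expected, and a reading at the limit is about as likely as a number. Among the measured compounds shown here, the only number, 10900 nM for compound 2, anchors the lower side of the expectation. The expected step is an at least 1.2-fold lower number from compound 3 to compound 4 (0.09 log units; that floor lies within the scatter). Compound 4 is estimated at 16000 nM, with an expected range of 7000 nM to 30000 nM.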

Compound 4, half-maximal inhibitory concentration: > 20000 nM
Compound 4 was reported as a limit; the forecaster's own chance of this, stated with the estimate: 55%; middle value at least 1.2-fold (0.09 log units) away from the limit.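

The change of 3-fluorophenyl for 4-fluoro-2,5-dimethylphenyl gives an at least 1.8-fold higher number from compound 2 to compound 4 (0.26 log units; that floor lies within the scatter) in this assay, so this second exchange away from compound 2 also ends at a limit rather than at a number. The steps from compound 3 and from compound 1 to compound 4 cannot be read, as both ends of each are limits. Placing two more carbon atoms on a fluorophenyl group at this aromatic carbon did not bring the reading to a number, and compound 2 remains the only compound shown with one, while the others share a single ceiling: the limit of > 20000 nM in this assay, at which 3 of the 4 values shown sit.

As far as these compounds go, how far compound 1, compound 3 and compound 4 lie past that limit stays open, so no order can be given among them, and the size of the methyl groups' contribution remains unknown. Also open, from the compounds shown here alone, is whether a plain phenyl, an amine or a carboxylic acid at this carbon would give a number, and whether any such group would match or improve on the reading of compound 2.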